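A few compounds are considered here, and "the series" means these few. Any claim that something is new, unique, unknown or untested is made for them only; others in the source may bear on it.

Compound 1 `Cc1ccc2nc(NC(C)C)nc(NCc3ccco3)c2c1`: in a physicochemical assay for solubility, at pH 2 (on this read-out lower numbers stand for lower solubility and higher numbers for higher solubility), compound 1 gives >= 30000 nM, which is a limit of the assay.
Compound 2 `Cc1cccc2nc(NC(C)C)nc(NCc3ccco3)c12`: in this assay compound 2 gives >= 30000 nM, also a limit.
Compound 3 `COc1ccc2nc(NC(C)C)nc(NCc3ccco3)c2c1`: in this assay compound 3 gives >= 30000 nM, again a limit.

From compound 1 to compound 3 the change is methoxy in place of methyl on an aromatic carbon, and the step that the two limits leave unreadable from compound 1 to compound 3 cannot be sized, because all three values sit at the limit of >= 30000 nM in this assay, at which 3 of the 3 values shown sit. How the cores of compound 1 and compound 2 differ is not broken down here. Compound 4 `COc1cccc2nc(NC(C)C)nc(NCc3ccco3)c12` is not yet measured; it arises from compound 2 by methoxy in place of methyl on an aromatic carbon, the same kind of change as before, though here the group sits ortho to a fused ring and meta to a fused ring rather than meta and para. The step from compound 2 to compound 4 is expected to be a number no higher from compound 2 to compound 4 (the limit leaves the size open). Compound 4 is expected to show 30000 nM in this assay.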

Compound 4, solubility: >= 30000 nM
Compound 4 was reported as a limit; the forecaster's own chance of this, stated with the estimate: 80%; the middle value sits exactly at the limit.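

The step between compound 2 and compound 4 cannot be read, because both values are limits: the limit of >= 30000 nM in this assay, at which 4 of the 4 values shown sit.

The compounds shown leave open how these four compare in this assay, and whether methoxy in place of methyl changes the read-out at all.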